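The compounds below may be only part of what the source reports. "The series", "measured", "known", "first", "only" and "open" are said of these compounds alone.

Measured so far:
compound 1, `O=c1c(-c2nn[nH]n2)c[nH]c2ccccc12`: in a functional assay on the whole organism (strain Sprague-Dawley) for inhibition, with Rattus norvegicus as the target (on this read-out higher numbers stand for an effect only at larger amounts of compound and lower numbers for an effect already at smaller amounts), compound 1 gives > 20 mg/kg, a limit of the assay rather than a number
compound 2, `COc1cccc2c(=O)c(-c3nn[nH]n3)c[nH]c12`: in this assay compound 2 gives 0.312 mg/kg

Among the compounds with values here, compound 2 carries the only number in this assay; the other value, (the limit of > 20 mg/kg in this assay, at which 1 of the 2 values shown sits), is a limit. Within the data shown here, the single measured step is an at least 64-fold lower number from compound 1 to compound 2 (1.80 log units; beyond the scatter). Compound 3, `CC(C)Oc1cccc2c(=O)c(-c3nn[nH]n3)c[nH]c12`, differs from compound 2 in that (isopropyl in place of methyl on an oxygen on an aromatic ring). Among the measured compounds shown here, no measured step exchanges methyl for isopropyl, so the one measured step gives no direct guide, and no step beyond the scatter is expected in either direction. The expected step is a 1.6-fold higher number from compound 2 to compound 3 (0.20 log units; within the scatter). For compound 3 the estimate in this assay is 0.5 mg/kg, with a range of 0.15 mg/kg to 2 mg/kg.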

Compound 3, minimum effective dose: 1.25 mg/kg
For compound 3 the middle estimate is 2.5-fold (0.40 log units) below the measured one, and the stated range covers the measured number.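

At the oxygen on the aromatic ring, the size of the alkyl group matters in this assay: isopropyl in place of methyl gives a 4.0-fold higher number from compound 2 to compound 3 (0.60 log units; beyond the scatter). Isopropoxy in place of hydrogen on the aromatic carbon still gives an at least 16-fold lower number from compound 1 to compound 3 (1.20 log units; beyond the scatter), so the large step seen with methoxy is not unique to methoxy. Compound 1 stands at a limit of the assay and not at a number: the limit of > 20 mg/kg in this assay, at which 1 of the 3 values shown sits.

Open, as far as these compounds go, is how ethoxy, a longer chain or an amine at this place would read. Also open, from the compounds shown here alone, is whether the oxygen itself is needed, as a plain methyl group on the aromatic carbon would show.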